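The source may report more compounds than this note shows. Statements on the series, on what has been measured and on what is new or still open speak of the compounds shown alone.

Among the measured compounds shown here, in an ADME assay on DU-145 cells (Homo sapiens) for cytotoxicity, read by MTT assay, with a stated time of 72 h (a lower number here means a stronger inhibitor, a higher number a weaker inhibitor), compound 1 `COc1ccc(OC)c(C2=C(c3cc(OC)c(OC)c(OC)c3)C(=O)CC2O[SiH2]C(C)(C)C)c1` gives 100 ug/mL, the only true number so far. Compound 2 `COc1cc(C2=C(c3ccc(SC)cc3)CC(O[SiH2]C(C)(C)C)C2=O)cc(OC)c1OC` reads > 100 ug/mL, which is a limit of the assay and not a number. Compound 3 `COc1ccc(OC)c(C2=C(c3cc(OC)c(OC)c(OC)c3)C(=O)CC2O)c1` reads > 100 ug/mL, also a limit. The series thus presses against (the limit of > 100 ug/mL in this assay, at which 2 of the 3 values shown sit). Compound 4 `COc1cc(C2=C(c3cc(C)c(OC)c(C)c3)C(O[SiH2]C(C)(C)C)CC2=O)cc(OC)c1OC` differs from compound 1 by one change: 4-methoxy-3,5-dimethylphenyl in place of 2,5-dimethoxyphenyl on a double-bonded ring carbon, with 4-methoxy-3,5-dimethylphenyl in place of 2,5-dimethoxyphenyl on a double-bonded ring carbon. For the measured compounds named here, the one measured step, a number no lower from compound 1 to compound 3 (the limit leaves the size open), has no readable size and lies on an oxygen on a saturated carbon, not at this place. The expected change in this assay is therefore none beyond the scatter, an estimated no change at the digits printed from compound 1 to compound 4 (within the scatter). For compound 4 the estimate is 100 ug/mL, within a range of 45 ug/mL to 200 ug/mL.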

Compound 4, half-maximal inhibitory concentration: > 100 ug/mL
Compound 4 was reported as a limit; the forecaster's own chance of this, stated with the estimate: 55%; the middle value sits exactly at the limit.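

This is the first step shown at this position, the double-bonded ring carbon, where 4-methoxy-3,5-dimethylphenyl replaces 2,5-dimethoxyphenyl: a number no lower from compound 1 to compound 4 (the limit leaves the size open) and it cannot be read in size. Compound 4 gives > 100 ug/mL which is a limit and not a number. Cytotoxicity in this assay therefore shows no measurable gain from this change, and the series sits ever more at one edge: the limit of > 100 ug/mL in this assay, at which 3 of the 4 values shown sit.

On these data alone, whether this position can affect the reading at all stays open. A phenyl ring carrying an amine or a carboxylic acid here might or might not give a true number in this assay.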